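The compounds below may be only part of what the source reports. "The series", "measured", "known", "first", "only" and "open" are said of these compounds alone.

Working notes on the series. In a functional assay on HeLa cells (Homo sapiens) for antiproliferative activity, read by MTT assay, with a stated time of 24 h (on this read-out higher numbers stand for weaker inhibition and lower numbers for stronger inhibition), compound 1 (`Cc1ccc(-c2nn(-c3ccccc3)cc2-c2nc3ccccc3n2S(=O)(=O)c2cc(C)ccc2C)cc1`) gives 370 nM and compound 3 (`Cc1ccc(C)c(S(=O)(=O)n2c(-c3cn(-c4ccccc4)nc3-c3ccc(F)cc3)nc3ccccc32)c1`) gives 320 nM. These two values lie within the scatter of each other and together form the low end of the three numbers. Compound 2 (`Cc1ccc(-c2nn(-c3ccccc3)cc2-c2nc3ccccc3n2S(=O)(=O)c2ccc(F)cc2)cc1`) gives 3670 nM, well apart from both.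

The next structure is compound 4 (`O=S(=O)(c1ccc(Br)cc1)n1c(-c2cn(-c3ccccc3)nc2-c2ccc(F)cc2)nc2ccccc21`), which differs from compound 3 thus: 4-bromophenyl in place of 2,5-dimethylphenyl on a sulfonyl sulfur. In words, 4-bromophenyl stands in place of 2,5-dimethylphenyl on a sulfonyl sulfur.

For the measured compounds named here, the closest precedent is a 9.9-fold higher number from compound 1 to compound 2 (1.00 log units; beyond the scatter), a step beyond the scatter, in which 4-fluorophenyl replaced the same 2,5-dimethylphenyl on the sulfonyl sulfur. The other measured step, a 1.2-fold lower number from compound 1 to compound 3 (0.06 log units; within the scatter), lies within the scatter, so compound 3 offers a comparable starting point to compound 1. Going by the values given here, no measured compound carries 4-bromophenyl, and the precedent rests on a single pair, so carrying it over is uncertain. A clear step towards a higher number is therefore expected in this assay, perhaps somewhat smaller than the precedent. The estimated change is a 6.9-fold higher number from compound 3 to compound 4 (0.84 log units; beyond the scatter). For compound 4 the estimated value is 2200 nM, with an expected range of 600 nM to 6500 nM.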

Compound 4, half-maximal inhibitory concentration: 2040 nM
For compound 4 the middle estimate is 1.1-fold (0.03 log units) above the measured one; low and high end bracket the measured number.
By their numbers in this assay, from the lowest: compounds 3 and 1 (each within the scatter of the next); then compounds 4 and 2 (each within the scatter of the next).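

In this assay, 4-bromophenyl in place of 2,5-dimethylphenyl on the sulfonyl sulfur gives a 6.4-fold higher number from compound 3 to compound 4 (0.80 log units; beyond the scatter), so a step beyond the scatter towards a higher number now appears with a second aryl group and on a second background, alongside a 9.9-fold higher number from compound 1 to compound 2 (1.00 log units; beyond the scatter). Across the four compounds shown, the two carrying 2,5-dimethylphenyl on the sulfonyl sulfur form the low end of the numbers, and the two carrying 4-fluorophenyl or 4-bromophenyl there form the high end, with no compound going against this split. No measurement in hand explains the step at this position.

Compounds 2 and 4 differ in more than one place, so the 4-fluorophenyl and 4-bromophenyl groups cannot be compared directly, and the series does not yet separate the effect of removing the two methyl groups from that of adding the halogen. From the compounds shown here alone, a plain phenyl on the sulfonyl sulfur would help to divide the step between those two parts, while a pyridyl group or a carbonyl in place of the sulfonyl remains open.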